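This account rests on a few compounds, and the source may have more. Where it says the series, first, only, none or still open, it means among the compounds named here.

Of the compounds shown here, three built on one shared core have been measured in a functional assay on NCI-H23 cells (Homo sapiens) for inhibition, read by sulforhodamine B assay, with a stated time of 48 h, tested at 10 uM; on this read-out higher numbers stand for more inhibition at the one concentration tested (going by the name of the read-out) and lower numbers for less inhibition. Compound 1 `c1ccc2c(-c3cn4ccnc4c(-c4ccc5ncn(C6CCCCC6)c5c4)n3)cccc2c1` gives 4.32%, compound 2 `c1cn2cc(-c3ccsc3)nc(-c3ccc4ncn(C5CCCCC5)c4c3)c2n1` gives 10%, and compound 3 `COc1ccccc1-c1cn2ccnc2c(-c2ccc3ncn(C4CCCCC4)c3c2)n1` gives 2.79%. Compound 3 thus stands lowest of the three numbers, yet both of its gaps to the others lie within the scatter: a number 1.5 percentage points lower from compound 1 to compound 3 (within the scatter) and a number 7.2 percentage points lower from compound 2 to compound 3 (within the scatter). The step forward leads to compound 4 `c1csc(-c2cn3ccnc3c(-c3ccc4ncn(C5CCCCC5)c4c3)n2)c1`, and the change is thiophen-2-yl in place of 2-methoxyphenyl on an aromatic carbon. The measured step that bears most directly on it, a number 7.2 percentage points lower from compound 2 to compound 3 (within the scatter), removes a closely related five-membered ring and installs the same 2-methoxyphenyl group, and it stayed within the scatter; the companion step a number 5.7 percentage points higher from compound 1 to compound 2 (within the scatter) was also within the scatter. Nothing among the three measured compounds therefore points to a move beyond the usual spread, and the expected step is a number 4.2 percentage points higher from compound 3 to compound 4 (within the scatter), the reversal of the related swap. Compound 4 is accordingly estimated at 7% in this assay, with a range from -4% to 18%.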

Compound 4, a percentage reported as inhibition, at one concentration (the size of the read-out at that concentration, not a potency): 5.95%
The estimate for compound 4 lay 1.1 percentage points above the measured number, within the range that was stated.
By their numbers in this assay, from the lowest: compounds 3, 1, 4 and 2 (each within the scatter of the next).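

At this position, next to the ring nitrogen, thiophen-2-yl gives a number 3.2 percentage points higher from compound 3 to compound 4 (within the scatter) and a number 1.6 percentage points higher from compound 1 to compound 4 (within the scatter) and a number 4.1 percentage points lower from compound 2 to compound 4 (within the scatter) in this assay, and all three steps lie within the scatter. The last step is the new kind of comparison, since it changes only the point of attachment on the thiophene ring, and even that does not separate the two isomers. Among the four aromatic groups shown, none can therefore be told apart here, and no evidence is available to explain this. On these data alone, all four groups at this position are aromatic rings on the same cyclohexyl-bearing core, so the response to a basic amine such as piperazine, or to a carboxylic acid, remains open. As far as these compounds go, it also remains open whether changing the cyclohexyl group elsewhere on the shared core would lift the read-out beyond the scatter.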